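Swapping dimethylamino for sulfanyl on a shared core

The source may report more compounds than this note shows. Statements on the series, on what has been measured and on what is new or still open speak of the compounds shown alone.

Measured so far:
- compound 1, `[N-]=[N+]=Nc1nccc2c1ncn2[C@H]1C[C@H](O)[C@@H](CO)O1`, 13%
- compound 2, `CNc1nccc2c1ncn2C1O[C@H](CO)[C@@H](O)[C@H]1O`, 11%
- compound 3, `CN(C)c1[nH]ccc2ncnc1-2`, 25%

All three were tested in a functional assay on EL4 cells (Mus musculus) for inhibition, tested at 100 uM; on this read-out higher numbers stand for more inhibition at the one concentration tested (going by the name of the read-out) and lower numbers for less inhibition. Compound 3 gives the highest number of the three; its gap to compound 1 and its larger gap to compound 2 both lie beyond the usual scatter of such measurements.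

The unmeasured compound 4, `Sc1[nH]ccc2ncnc1-2`, differs from compound 3 in one place: sulfanyl in place of dimethylamino on an aromatic carbon. Going by the values given here, no measured pair shows this kind of swap, so its effect is unknown from the data.

With nothing to anchor the direction, a modest decrease from compound 3 seems a reasonable expectation, as a number 10 percentage points lower from compound 3 to compound 4 (within the scatter), bringing compound 4 closer to compound 1 and compound 2. Compound 4 is therefore estimated at 15%, expected to fall between 3% and 30%.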

Compound 4, a percentage reported as inhibition, at one concentration (the size of the read-out at that concentration, not a potency): < 5%
Compound 4 ended at the assay's limit; the forecaster's own chance of this, stated with the estimate: 5%; at least 10 percentage points between middle value and limit.
By their numbers in this assay, from the lowest: compounds 2 and 1 (each within the scatter of the next); then compound 3. At a limit, below all of these: compound 4.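

Going by these compounds alone, compound 4 is the first one-place change here, and it shows that the group on this aromatic carbon, next to the ring nitrogen, matters in this assay. Putting sulfanyl in place of dimethylamino gives a number at least 20 percentage points lower from compound 3 to compound 4 (beyond the scatter). In this assay compound 4 gives < 5%, a limit and not a number, so the step's full size cannot be read: the limit of < 5% in this assay, at which 1 of the 4 values shown sits.

From the compounds shown here alone, whether the drop comes from losing dimethylamino or from gaining sulfanyl stays open. So does how a methoxy or diethylamino group on this same carbon of the shared core would read.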